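The compounds below may be only part of what the source reports. "The series", "measured", "known", "first", "only" and "open" are said of these compounds alone.

Two compounds of the series carry measurements. Compound 1 `CCCCc1ccc(NS(=O)(=O)c2ccc(N3CCNC3=O)cc2)cc1` gives 450 nM in a functional assay on M21 cells (Homo sapiens) for antiproliferative activity, read by sulforhodamine B assay, with a stated time of 48 h; a lower number here means a stronger inhibitor, a higher number a weaker inhibitor. Compound 2 `O=C1NCCN1c1ccc(S(=O)(=O)Nc2cccc(Br)c2)cc1` gives 59 nM in this assay; this is the lower of the two numbers, and the gap to compound 1 lies beyond the usual scatter. Within the data shown here, the two measured compounds differ in more than one place, so no single step between them can be read off.

Compound 3 `COc1cccc(NS(=O)(=O)c2ccc(N3CCNC3=O)cc2)c1` has not yet been measured. Relative to compound 2 the change is methoxy in place of bromo on an aromatic carbon. Among the measured compounds shown here, nothing in the measured pair speaks directly to this exchange; the bromo of compound 2 is the only group of that kind seen so far, with a value of 59 nM. A modest loss is expected, a step of a 2.7-fold higher number from compound 2 to compound 3 (0.43 log units; beyond the scatter) in this assay, probably somewhat beyond the scatter. Compound 3 is estimated at 160 nM, with a range from 50 nM to 500 nM.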

Compound 3, half-maximal inhibitory concentration: 65 nM
Estimate against measurement, compound 3: 2.5-fold (0.39 log units) above, and the stated range covers the measured number.
By their numbers in this assay, from the lowest: compounds 2 and 3 (each within the scatter of the next); then compound 1.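

In this assay, methoxy in place of bromo gives a 1.1-fold higher number from compound 2 to compound 3 (0.04 log units; within the scatter), so the 3-bromophenyl and 3-methoxyphenyl compounds cannot be told apart. This position on the aromatic ring therefore accepts two different groups at one level: bromo, and methoxy with its extra heavy atom and its hydrogen-bond acceptor. Compound 2 and compound 3 together form the low end of the numbers seen so far, and no measurement of any property of these groups is at hand to account for the result.

Two groups do not show how far this tolerance extends. As far as these compounds go, whether an amine, a carboxylic acid or a longer alkoxy chain on the same aromatic carbon would stay at this level remains open.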